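Chloro gives way to ethoxy in compound 3

This account rests on a few compounds, and the source may have more. Where it says the series, first, only, none or still open, it means among the compounds named here.

Compound 1 (`COc1cc(C(=O)c2sc3ccccc3c2-c2ccc(F)cc2)cc(OC)c1OC`) gives 3200 nM 
Compound 2 (`COc1cc(C(=O)c2sc3ccccc3c2Nc2ccc(Cl)cc2)cc(OC)c1OC`) gives 3100 nM 

Among the compounds with values here, in a functional assay on A549 cells (Homo sapiens) for antiproliferative activity, read by MTT assay, with a stated time of 72 h (on this read-out lower numbers stand for stronger inhibition and higher numbers for weaker inhibition), compound 2 stands level with compound 1, and a 1.0-fold lower number from compound 1 to compound 2 (0.01 log units; within the scatter) is the only measured step, lying within the scatter. Compound 3 (`CCOc1ccc(Nc2c(C(=O)c3cc(OC)c(OC)c(OC)c3)sc3ccccc23)cc1`) carries one change from compound 2 (ethoxy in place of chloro on an aromatic carbon), ethoxy in place of chloro on an aromatic carbon. The measured step concerns a different exchange and does not test this one, so no shift beyond the scatter is expected in either direction. The expected change is a 1.1-fold lower number from compound 2 to compound 3 (0.04 log units; within the scatter) and it remains uncertain. Compound 3 is estimated at 2800 nM with a range of 900 nM to 8000 nM expected.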

Compound 3, half-maximal inhibitory concentration: 1400 nM
For compound 3 the middle estimate is 2.0-fold (0.30 log units) above the measured one; the measured number falls inside the stated range.
By their numbers in this assay, from the lowest: compound 3; then compounds 2 and 1 (each within the scatter of the next).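

In this assay, within the data shown here, ethoxy in place of chloro brings a 2.2-fold lower number from compound 2 to compound 3 (0.35 log units; beyond the scatter) and thus gives the first change beyond the scatter, showing that this aromatic carbon, para to a large group, responds to its substituent. The (4-ethoxyphenyl)amino group likewise brings a 2.3-fold lower number from compound 1 to compound 3 (0.36 log units; beyond the scatter) when set against 4-fluorophenyl. No evidence here accounts for either shift.

The compounds shown leave open whether the oxygen or the ethyl part of ethoxy carries the change. They also leave open how methoxy, a longer alkoxy chain or an amine would read at this place.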